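Shortening the chain of a pyrazole hydroxamic acid

A few compounds are considered here, and "the series" means these few. Any claim that something is new, unique, unknown or untested is made for them only; others in the source may bear on it.

Compound 1 `O=C(CCCCCNC(=O)c1cc(-c2ccc(F)cc2)[nH]n1)NO`: 7090 nM
Compound 2 `Cc1cc(-c2ccc(F)cc2)nn1Cc1ccc(C(=O)NO)cc1`: 11400 nM

In a functional assay on A549 cells (Homo sapiens) for antiproliferative activity, read by MTT assay, with a stated time of 96 h (a higher number here means a weaker inhibitor of growth, a lower number a stronger inhibitor of growth), compound 1 gives 7090 nM, the lower of the two numbers recorded; compound 2, with 11400 nM, sits within the scatter of it, so the two cannot be told apart. Compound 3 `O=C(CCCCNC(=O)c1cc(-c2ccc(F)cc2)[nH]n1)NO` differs from compound 1 in one place: hydroxycarbamoyl in place of (hydroxycarbamoyl)methyl on a saturated chain carbon, four bonds along the chain from an amide-type nitrogen. Among the measured compounds shown here, no step between two measured compounds bears on this change, so there is nothing in the recorded numbers to fix its direction or size. For compound 3 a step of a 1.6-fold higher number from compound 1 to compound 3 (0.19 log units; within the scatter) in this assay is expected, a modest move toward a higher number that may well stay inside the scatter. The estimate for compound 3 in this assay is 11000 nM, with a range from 4000 nM to 30000 nM.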

Compound 3, concentration for 50% growth inhibition: > 100000 nM
Compound 3 gave a limit, no number (the forecaster's own chance of this, stated with the estimate: 10%); at least 9.0-fold (0.95 log units) between middle value and limit.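

In this assay, putting hydroxycarbamoyl in place of (hydroxycarbamoyl)methyl on this saturated chain carbon, four bonds along the chain from an amide-type nitrogen, gives an at least 14-fold higher number from compound 1 to compound 3 (1.14 log units; beyond the scatter) and so counts as a large change. Compound 3 gives a limit of the assay and not a number: the limit of > 100000 nM in this assay, at which 1 of the 3 values shown sits. The earlier compounds shown here said nothing about this position, and the pair now shows that the chain length of compound 1 is not interchangeable with the shorter chain of compound 3 in this series.

On these data alone, whether a longer chain than that of compound 1 would hold or change the growth inhibition remains open, as does the effect of a carboxylic acid or an amine in place of the hydroxycarbamoyl end. The values shown measure growth inhibition alone, so they do not tell where the loss arises.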